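The compounds below may be only part of what the source reports. "The series", "measured", "known", "first", "only" and "open" are said of these compounds alone.

Measured compounds:
compound 1 `O=C(/C=C/c1ccco1)c1ccc(NC(=O)c2ccccc2)cc1` gives 59000 nM in a functional assay on HCT-116 cells (Homo sapiens) for cytotoxicity, read by resazurin assay, with a stated time of 48 h; on this read-out higher numbers stand for an effect only at larger amounts of compound and lower numbers for an effect already at smaller amounts
compound 2 `O=C(/C=C/c1cccc([N+](=O)[O-])c1)c1ccc(NC(=O)c2ccco2)cc1` gives 4100 nM in this assay

Of the two numbers shown, compound 2 has the lower one, and the gap between compound 1 and compound 2 is wider than the usual scatter of this kind of measurement. Compound 3 `O=C(/C=C/c1cccc([N+](=O)[O-])c1)c1ccc(NC(=O)c2ccccc2)cc1` has not yet been measured. It is built from compound 2 by a single change: phenyl in place of furan-2-yl on a carbonyl carbon. The rest of the molecule, including the part that carries the nitro group, stays as it is in compound 2. Within the data shown here, compound 1 and compound 2 differ in two places at once, so no measured pair shows what this one change does on its own. An expectation for compound 3 can therefore rest only on the fact that the change is small and leaves most of the molecule untouched; the step of a 1.5-fold higher number from compound 2 to compound 3 (0.17 log units; within the scatter) is expected to be modest, if anything toward a somewhat higher number. Compound 3 is accordingly expected to give 6000 nM, within a range from 1500 nM to 20000 nM.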

Compound 3, half-maximal effective concentration: 25000 nM
Estimate against measurement, compound 3: 4.2-fold (0.62 log units) below, and the stated range ends below it.
By their numbers in this assay, from the lowest: compound 2; then compound 3; then compound 1.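

In this assay, phenyl in place of furan-2-yl on the carbonyl carbon bound to the amide-type nitrogen gives a 6.1-fold higher number from compound 2 to compound 3 (0.79 log units; beyond the scatter) on its own, so this position responds to the change and the pair favours furan-2-yl. With phenyl kept on that carbonyl carbon, 3-nitrophenyl in place of furan-2-yl on the double-bonded chain gives a 2.4-fold lower number from compound 1 to compound 3 (0.37 log units; beyond the scatter) as a second single-place comparison, so the group on that chain matters too. Nothing given here explains either step.

Still open, going by these compounds, is how other groups on the same carbonyl carbon would compare, such as a thiophen-2-yl ring or a plain methyl. Also open, on these data alone, is whether the two steps would hold unchanged with the other group in place.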